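Benzamido in place of nitro: compound 3

This account rests on a few compounds, and the source may have more. Where it says the series, first, only, none or still open, it means among the compounds named here.

Measured in a functional assay on HCC827 cells (Homo sapiens) for cytotoxicity, read by MTT assay, with a stated time of 72 h; on this read-out lower numbers stand for stronger inhibition and higher numbers for weaker inhibition:
- Compound 1 `CC(C)n1c(Nc2ccccc2)nc2cnc(Nc3ccc(N4CCN(C)CC4)cc3)nc21` gives 0.1 nM
- Compound 2 `CN1CCN(c2ccc(Nc3ncc4nc(Nc5cccc([N+](=O)[O-])c5)n(C5CCCC5)c4n3)cc2)CC1` gives < 0.01 nM (a limit)

Compound 2 has no exact number, as its < 0.01 nM is a limit of this assay and nothing more. As far as these compounds go, compound 2 therefore stands at the limit of < 0.01 nM in this assay, at which 1 of the 2 values shown sits, and its true distance from compound 1 stays open.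

Compound 3 `CN1CCN(c2ccc(Nc3ncc4nc(Nc5cccc(NC(=O)c6ccccc6)c5)n(C5CCCC5)c4n3)cc2)CC1` takes benzamido in place of nitro on an aromatic carbon, as counted in benzamido in place of nitro on an aromatic carbon, with the rest of compound 2 unchanged.

Among the compounds with values here, no measured step covers such a change, so any expectation in this assay is loose. Within the data shown here, compound 1 gives 0.1 nM and is the only exact reading available as an anchor. The estimated change is an at least 3.0-fold higher number from compound 2 to compound 3 (0.47 log units; beyond the scatter) toward weaker inhibition, modest in size. For compound 3 the expected value is 0.03 nM, with an estimated span from 0.005 nM to 0.3 nM as the likely range.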

Compound 3, half-maximal inhibitory concentration: 15 nM
For compound 3 the middle estimate is 500-fold (2.70 log units) below the measured one; measured number above the stated range.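

In this assay, benzamido in place of nitro gives an at least 1500-fold higher number from compound 2 to compound 3 (3.17 log units; beyond the scatter), which shows that this position, on an aromatic carbon meta to a large group, is far from indifferent to what it carries. Within the data shown here, the earlier compounds offered no step at this position, so this is the first direct reading of its sensitivity. Compound 2 stands at a limit of the assay, so the step gives only a floor and its true size stays open: the limit of < 0.01 nM in this assay, at which 1 of the 3 values shown sits.

This single change does not separate the loss of nitro from the arrival of the amide link and the added aromatic ring. As far as these compounds go, whether a plain amine, a small acetamido group or a methoxy group at this position would stay close to compound 2 or fall toward compound 3 remains open.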